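The source may hold more compounds than are shown below. What is called first, only, known or untested is meant among the compounds shown, and "the series" means these compounds.

Within the data shown here, in a functional assay on NCI/ADR-RES cells (Homo sapiens) for inhibition, read by luminescence, with a stated time of 72 h (on this read-out lower numbers stand for stronger inhibition and higher numbers for weaker inhibition), two compounds have numbers so far. Compound 1 (`Nc1ncnc2c1nc(Sc1cc3c(cc1Br)CCO3)n2CCC1CCN(C=O)CC1`) gives 1800 nM as the lower of the two, and compound 2 (`C[C@H](O)C(=O)N1CCC(CCn2c(Sc3cc4c(cc3Br)CCO4)nc3c(N)ncnc32)CC1`) gives 11000 nM as the higher. Among the measured compounds shown here, putting 1-hydroxyethyl in place of hydrogen on a carbonyl carbon gives a 6.1-fold higher number from compound 1 to compound 2 (0.79 log units; beyond the scatter) and this modest change is the only measured step. Compound 3 (`Nc1ncnc2c1nc(Sc1cc3c(cc1Br)OCC3)n2CCC1CCN(C=O)CC1`) has not yet been measured. It differs from compound 1 on a sulfur whose other neighbours are: aromatic carbon. The change there is a group of 10 heavy atoms (8 carbon, 1 oxygen, 1 bromine; one five-membered non-aromatic ring with 1 hetero atom, one six-membered aromatic ring of carbon only) in place of a group of 10 heavy atoms (8 carbon, 1 oxygen, 1 bromine; one five-membered non-aromatic ring with 1 hetero atom, one six-membered aromatic ring of carbon only), on a sulfur and the two compounds have the same atoms, joined differently. For the measured compounds named here, the measured step lies at a carbonyl carbon and not on that sulfur, so it gives no direct measure of this change, and no measured pair tests it. With no evidence pointing firmly either way, the expected outcome is a 1.2-fold higher number from compound 1 to compound 3 (0.09 log units; within the scatter) and no step beyond the scatter is expected. Compound 3 is estimated at 2200 nM with an expected range from 650 nM to 7500 nM in this assay once it is measured.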

Compound 3, half-maximal inhibitory concentration: 86000 nM
Compound 3: middle estimate off by 39-fold (1.59 log units), on the low side, outside the stated range (above it).
By their numbers in this assay, from the lowest: compound 1; then compound 2; then compound 3.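

In this assay, the position on a sulfur whose other neighbours are: aromatic carbon proves highly sensitive to how the attached group is joined, with a 48-fold higher number from compound 1 to compound 3 (1.68 log units; beyond the scatter). The group that enters and the group that leaves have the same 10 heavy atoms, the same two rings and the same counts of hydrogen-bond donors and acceptors, so composition and these counts alone do not account for the difference between the two compounds, and this step is classed as large, whereas the earlier step at the carbonyl carbon, a 6.1-fold higher number from compound 1 to compound 2 (0.79 log units; beyond the scatter), is classed as modest. Among these compounds, nothing measured here explains why the arrangement in compound 1 gives so much lower a number than the one in compound 3.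

The compounds shown leave open whether the same rearrangement would have an effect of similar size with the 1-hydroxyethyl group on the carbonyl carbon, as in compound 2. They also do not show how this position would respond to chlorine in place of the bromine, or to a methoxy group on the aromatic ring in place of the five-membered non-aromatic ring.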